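From 2-chlorophenyl to methyl on a shared core

A few compounds are considered here, and "the series" means these few. Any claim that something is new, unique, unknown or untested is made for them only; others in the source may bear on it.

Compound 1 `Fc1cccc(F)c1Cn1ccc2nc(-c3c(F)cccc3F)nc-2c1`: > 100000 nM
Compound 2 `Clc1ccccc1Cn1ccc2nc(-c3ccccc3)nc-2c1`: > 100000 nM
Compound 3 `FC(F)(F)c1ccccc1Cn1ccc2nc(-c3ccccc3)nc-2c1`: > 100000 nM

In an ADME assay on MDBK cells (Bos taurus) for cytotoxicity (on this read-out higher numbers stand for lower toxicity in this test and lower numbers for higher toxicity in this test), each of these three values is a limit of the assay and not a number. Compound 2 stands at that limit, and the two other compounds stand there as well, as the limit of > 100000 nM in this assay, at which 3 of the 3 values shown sit, records. For the measured compounds named here, the only measured step between close neighbours, a step that the two limits leave unreadable from compound 2 to compound 3, is therefore of unreadable size.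

Compound 4 `CCn1ccc2nc(-c3ccccc3)nc-2c1` has not been measured. It differs from compound 2 in one place: methyl in place of 2-chlorophenyl on a saturated chain carbon bound to an aromatic nitrogen. Going by the values given here, no measured step bears on this change, and the one step known gives no readable size, so no direction beyond the scatter can be expected. Compound 4 is therefore estimated at 150000 nM, with a range from 50000 nM to 500000 nM, the expected step being a step that the limit leaves unreadable from compound 2 to compound 4.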

Compound 4, half-maximal cytotoxic concentration: > 100000 nM
Compound 4 ended at the assay's limit; the forecaster's own chance of this, stated with the estimate: 85%; the middle value lies beyond the limit too.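

Compound 2 and compound 4 both stand at a limit and not at a number, so no size can be read for the step between them: the limit of > 100000 nM in this assay, at which 4 of the 4 values shown sit.

The compounds shown leave open whether any change on the shared core gives a readable number in this assay.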